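Compound 2 and the Step to Compound 3

The source may hold more compounds than are shown below. What is called first, only, known or untested is meant among the compounds shown, and "the series" means these compounds.

Compound 1 `COc1cc(-c2ccnc3cc(-c4ccc5cc[nH]c5c4)nn23)cc(OC)c1OC` gives 187 nM
Compound 2 `C=Cc1ccc(-c2cc3nccc(-c4cc(OC)c(OC)c(OC)c4)n3n2)cc1` gives 1060 nM

In a functional assay on HCT-116 cells (Homo sapiens) for inhibition, read by CCK-8 assay, with a stated time of 48 h (on this read-out higher numbers stand for weaker inhibition and lower numbers for stronger inhibition), compound 2 stands at 1060 nM and holds the higher of the two numbers, which means the weaker inhibition. Compound 3 `COc1cc(-c2ccnc3cc(-c4cccc(C)c4)nn23)cc(OC)c1OC` keeps the shared core and differs from compound 2 as follows: 3-methylphenyl in place of 4-vinylphenyl on an aromatic carbon. In short, 3-methylphenyl enters in place of 4-vinylphenyl on an aromatic carbon. Within the data shown here, one measured step bears on this, a 5.7-fold higher number from compound 1 to compound 2 (0.75 log units; beyond the scatter), which lies beyond the scatter and arose at the same carbon. Among the measured compounds shown here, it shows that changing this group can shift the number, but no measured compound carries 3-methylphenyl. With compound 2 at the top of the two numbers, a modest move to a lower number is expected. The expected change is a 2.4-fold lower number from compound 2 to compound 3 (0.37 log units; beyond the scatter) in this assay. For compound 3 the estimate is 450 nM, with an expected range from 130 nM to 1500 nM.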

Compound 3, half-maximal inhibitory concentration: 6150 nM
Beside the measured number, compound 3's estimate is 14-fold (1.14 log units) below it, and the stated range ends below it.
By their numbers in this assay, from the lowest: compound 1; then compound 2; then compound 3.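

In this assay, the change from 4-vinylphenyl to 3-methylphenyl gives a 5.8-fold higher number from compound 2 to compound 3 (0.76 log units; beyond the scatter), showing that two groups of similar size, each with one six-membered aromatic ring of carbon only, can still differ clearly at this carbon. Measured against 1H-indol-6-yl, the same 3-methylphenyl group gives a 33-fold higher number from compound 1 to compound 3 (1.52 log units; beyond the scatter), a large step that widens the spread at this one position and leaves compound 1 with the lowest number of the three. Nothing measured here accounts for these differences.

The compounds shown leave open how 4-methylphenyl would stand, which would help separate the effect of the methyl group from that of its place on the ring. From the compounds shown here alone, whether an amine or a carboxylic acid on this phenyl ring would bring the number closer to that of compound 1 also remains open.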